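From Aminophenyl to Carboxyphenyl in a Cytotoxicity Test

A few compounds are considered here, and "the series" means these few. Any claim that something is new, unique, unknown or untested is made for them only; others in the source may bear on it.

Of the compounds shown here, three have been measured so far, and none of them gives a firm number. In an ADME assay on CEMx174 cells (Homo sapiens) for cytotoxicity (on this read-out lower numbers stand for higher toxicity in this test and higher numbers for lower toxicity in this test), compound 1 (`CC1=C(C(=O)OCc2ccccc2)C(c2cccc(O)c2)NC(=O)N1`) gives > 10000 nM, which is a limit of the assay and not a number. In this assay compound 2 (`Cc1nc(=O)[nH]c(-c2cccc(O)c2)c1C(=O)OCC1CCCCC1`) gives > 10000 nM, again a limit. In this assay compound 3 (`CCC1=C(C(=O)OCC2CCCCC2)C(c2cccc(N)c2)NC(=O)N1`) gives > 10000 nM, also a limit. Compound 3 therefore has no exact value of its own, and its standing is summed up by the limit of > 10000 nM in this assay, at which 3 of the 3 values shown sit.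

Compound 4 (`CCC1=C(C(=O)OCC2CCCCC2)C(c2ccc(C(=O)O)cc2)NC(=O)N1`) has not yet been measured. It differs from compound 3 in a single place, on a saturated ring carbon of a six-membered non-aromatic ring with 2 nitrogen: 4-carboxyphenyl in place of 3-aminophenyl on a saturated ring carbon. Going by the values given here, no pair of measured compounds differing in one place is available as a guide, so no direction of change can be drawn from the data. No shift beyond the usual scatter is expected in this assay, and the result will probably be another limit. That expectation rests on (the limit of > 10000 nM in this assay, at which 3 of the 3 values shown sit). The expected change is a step that the limit leaves unreadable from compound 3 to compound 4. The estimate for compound 4 is 12000 nM, with an expected range from 6000 nM to 40000 nM.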

Compound 4, half-maximal cytotoxic concentration: > 10000 nM
Compound 4: only a limit was reported; the forecaster's own chance of this, stated with the estimate: 85%; the middle value does not contradict the limit.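

Compound 3 and compound 4 both stop at a limit in this assay, so no step can be read for 4-carboxyphenyl in place of 3-aminophenyl. Every compound shown ends the same way: the limit of > 10000 nM in this assay, at which 4 of the 4 values shown sit.

What the compounds shown leave open is how far each lies from that limit, and which change, if any, would give a firm number.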